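Replacing the Dichlorophenylamino Arm with Phenyl: Compound 3

A few compounds are considered here, and "the series" means these few. Any claim that something is new, unique, unknown or untested is made for them only; others in the source may bear on it.

Compound 1 `COc1cc(-c2nn(-c3cccc(NC(=O)Nc4ccc(Cl)c(Cl)c4)c3)cc2-c2ccncc2)ccc1Cl`: 2470 nM
Compound 2 `O=C(Nc1cccc(-n2cc(-c3ccncc3)c(-c3ccc(Cl)c(O)c3)n2)c1)Nc1ccc(Cl)c(Cl)c1`: 9680 nM

Among the compounds with values here, in a functional assay on U-251 cells (Homo sapiens) for inhibition, read by sulforhodamine B assay, with a stated time of 48 h (a lower number here means a stronger inhibitor of growth, a higher number a weaker inhibitor of growth), compound 1 gives 2470 nM, the lowest of the two numbers measured so far. Within the data shown here, compound 2 gives 9680 nM, and the single measured step between them is a 3.9-fold higher number from compound 1 to compound 2 (0.59 log units; beyond the scatter), a change of a methyl to hydrogen on an oxygen of an aromatic ring. Compound 3 `COc1cc(-c2nn(-c3cccc(NC(=O)c4ccccc4)c3)cc2-c2ccncc2)ccc1Cl` has not been measured. It differs from compound 1 in one place: phenyl in place of (3,4-dichlorophenyl)amino on a carbonyl carbon. Among the measured compounds shown here, no measured step touches this part of the shared core; the only step available concerns a different position, so it gives no direct guide to the size or direction of the new change. With the (3,4-dichlorophenyl)amino group and its hydrogen-bond donor removed, compound 3 is expected to give a higher number than compound 1 in this assay, though the expectation rests on little. The step is estimated as a 2.8-fold higher number from compound 1 to compound 3 (0.45 log units; beyond the scatter). Compound 3 is therefore estimated at 7000 nM, with a range from 2000 nM to 30000 nM.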

Compound 3, concentration for total growth inhibition: 30800 nM
Compound 3: the middle estimate sits 4.4-fold (0.64 log units) below what was measured; the whole stated range lies below it.
By their numbers in this assay, from the lowest: compound 1; then compound 2; then compound 3.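

At the carbonyl carbon, in this assay, putting phenyl in place of (3,4-dichlorophenyl)amino gives a 12-fold higher number from compound 1 to compound 3 (1.10 log units; beyond the scatter), so this arm weighs heavily on growth inhibition, and this step is larger than the only earlier one, made on an oxygen of an aromatic ring, a 3.9-fold higher number from compound 1 to compound 2 (0.59 log units; beyond the scatter). Compound 3 keeps a six-membered aromatic ring of carbon only on the carbonyl carbon, so such a ring there does not by itself preserve the number of compound 1; the nitrogen, the chlorine atoms and the hydrogen-bond donor of the (3,4-dichlorophenyl)amino group all leave in the same single change. No measurement available speaks to the reason for this step.

The compounds shown cannot separate the part played by that nitrogen from the part played by the two chlorine atoms, since a plain phenylamino group or a 3,4-dichlorophenyl group on the carbonyl carbon does not appear among them. Nor do they show whether a non-aromatic amine such as morpholine, or a longer chain such as benzylamino, could take the place of the (3,4-dichlorophenyl)amino group at this carbonyl carbon.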